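A few compounds are considered here, and "the series" means these few. Any claim that something is new, unique, unknown or untested is made for them only; others in the source may bear on it.

Working notes on the amide series. Three members have numbers in a functional assay on HL-60 cells (Homo sapiens) for inhibition, read by MTT assay, with a stated time of 72 h (on this read-out higher numbers stand for weaker inhibition and lower numbers for stronger inhibition), so far. Compound 1 `Cc1nc(-c2ccccc2)c(C(=O)N2CCN(c3ccc(Cl)c(Cl)c3)CC2)o1` gives 124 nM in this assay, compound 2 `Cc1nc(-c2ccccc2)c(C(=O)N2CCN(c3cccc(C(F)(F)F)c3)CC2)o1` gives 153 nM, and compound 3 `Cc1nc(-c2ccccc2)c(C(=O)N2CCN(c3ccc(C)c(C)c3)CC2)o1` gives 43 nM. Compound 3 carries the lowest number of the three, and both steps toward it lie beyond the scatter: a 2.9-fold lower number from compound 1 to compound 3 (0.46 log units; beyond the scatter) and a 3.6-fold lower number from compound 2 to compound 3 (0.55 log units; beyond the scatter). The step between the other two, a 1.2-fold higher number from compound 1 to compound 2 (0.09 log units; within the scatter), stays within the scatter.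

Compound 4 `COc1cccc(N2CCN(C(=O)c3oc(C)nc3-c3ccccc3)CC2)c1` is not yet measured in this assay. It differs from compound 3 in one place: 3-methoxyphenyl in place of 3,4-dimethylphenyl on an amine nitrogen in a ring.

Among the measured compounds shown here, the steps that bear on this change are the two that end at compound 3, since each of them exchanges the 3,4-dimethylphenyl for another aryl group on the same ring nitrogen, and each gave a modest rise when read in reverse. For the measured compounds named here, no step involving a 3-methoxyphenyl exists in this set, so the direction rests only on the observation that the two other aryl groups tried both give higher numbers than compound 3 in this assay. Compound 4 is therefore expected to show a 2.1-fold higher number from compound 3 to compound 4 (0.32 log units; beyond the scatter), a modest step upward rather than none. The estimate for compound 4 in this assay is 90 nM, with a range from 40 nM to 220 nM.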

Compound 4, half-maximal inhibitory concentration: 34.8 nM
Compound 4: the middle estimate sits 2.6-fold (0.41 log units) above what was measured; measured number outside the range, below it.
By their numbers in this assay, from the lowest: compounds 4 and 3 (each within the scatter of the next); then compounds 1 and 2 (each within the scatter of the next).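

In this assay the aryl group on the ring nitrogen accepts more than the first three compounds showed: the exchange of 3,4-dimethylphenyl for 3-methoxyphenyl gives (a 1.2-fold lower number from compound 3 to compound 4 (0.09 log units; within the scatter)), so compound 3 no longer stands alone at the low end and an aryl group with a hydrogen-bond acceptor sits level with one that has none. Measured against the other two aryl groups, 3-methoxyphenyl gives (a 4.4-fold lower number from compound 2 to compound 4 (0.64 log units; beyond the scatter)) and (a 3.6-fold lower number from compound 1 to compound 4 (0.55 log units; beyond the scatter)), which divides the four compounds into two pairs, compounds 3 and 4 on one side and compounds 1 and 2 on the other. No measurement here bears on why the aryl groups fall into these two pairs.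

On these data alone, whether a plain phenyl or a pyridine on the ring nitrogen would join compounds 3 and 4 remains open, as does whether an ethoxy or a hydroxy group in place of the methoxy would keep the number at that level. All four compounds share one core and one amide link, so the series says nothing yet about how changes there would read out.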